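The source may report more compounds than this note shows. Statements on the series, on what has been measured and on what is new or still open speak of the compounds shown alone.

Among the measured compounds shown here, in a functional assay on SMMC-7721 cells (Homo sapiens) for antiproliferative activity, read by MTT assay, with a stated time of 48 h (a higher number here means a weaker inhibitor, a lower number a stronger inhibitor), three compounds with a shared core have numbers so far. Compound 1 (`CC(=O)OC/C1=C/C[C@](C)(CCC=C(C)C)/C=C/[C@@H](OC(=O)C=C(C)C)[C@](C)(OC(C)=O)/C=C/C1=O`) gives 4130 nM and compound 2 (`CO[C@]1(C)/C=C/C(=O)/C(CO)=C\C[C@](C)(CCC=C(C)C)/C=C/[C@H]1OC(=O)C=C(C)C`) gives 15800 nM in these measurements. Compound 3 (`CC(C)=CCC[C@]1(C)/C=C/[C@@H](OC(=O)C=C(C)C)[C@](C)(O)/C=C/C(=O)/C(CN(C)C)=C\C1`) gives 820 nM and so holds the lowest number of the three, a stronger result than the other two by gaps beyond the usual scatter. These compounds differ from one another in more than one place, so their numbers cannot single out the contribution of any one group.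

Compound 4 (`CC(C)=CCC[C@]1(C)/C=C/[C@@H](OC(=O)C=C(C)C)[C@](C)(O)/C=C/C(=O)/C(C[Si](C)(C)C(C)(C)C)=C\C1`) differs from compound 3 in one place only, and a group of 7 heavy atoms (6 carbon, 1 silicon; no ring) in place of a group of 3 heavy atoms (2 carbon, 1 nitrogen; no ring), on a saturated chain carbon bound to a double-bonded ring carbon is the whole change. The dimethylamino group leaves, and the larger silicon-bearing group takes its place. For the measured compounds named here, no measured pair shows this swap directly, so the expectation rests on thin evidence. Among the measured compounds, only compound 3 at 820 nM carries dimethylamino, while compound 1 without it stands at 4130 nM and differs elsewhere as well.

A moderate move toward a weaker inhibitor is expected, estimated as a 3.4-fold higher number from compound 3 to compound 4 (0.53 log units; beyond the scatter) in this assay on this limited basis. Compound 4 is estimated at 2800 nM with an expected range from 700 nM to 11000 nM once measured.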

Compound 4, half-maximal inhibitory concentration: 4000 nM
Beside the measured number, compound 4's estimate is 1.4-fold (0.15 log units) below it; measured number inside the range.
By their numbers in this assay, from the lowest: compound 3; then compounds 4 and 1 (each within the scatter of the next); then compound 2.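

In this assay, among the compounds shown here, the swap of dimethylamino for the group of 7 heavy atoms (6 carbon, 1 silicon), on a saturated chain carbon bound to a double-bonded ring carbon, brings a 4.9-fold higher number from compound 3 to compound 4 (0.69 log units; beyond the scatter) and is the only change in this set that can be read on its own. The earlier compounds shown here differed in more than one place, so they could not show that this group alone moves the number; with everything else held the same, this pair shows that it does, and that dimethylamino gives the lower number of the two. Nothing measured here accounts for the step, so this single pair cannot tell which difference between the two groups matters.

The compounds shown leave open whether a diethylamino group, a longer carbon chain or a methoxy group in this place would give a number closer to that of compound 3 or to that of compound 4. They also leave open whether the same swap would shift the number to a similar extent in compound 1 or compound 2, which carry other groups elsewhere on the shared core.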